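The source may hold more compounds than are shown below. What is called first, only, known or untested is meant among the compounds shown, and "the series" means these compounds.

Compound 1 `Cc1c(F)c(N)c2c(=O)cc(-c3ccc(N)c(F)c3)oc2c1F` gives 13 nM in a functional assay on MCF7 cells (Homo sapiens) for cytotoxicity, read by neutral red uptake, with a stated time of 3 days (a higher number here means a weaker inhibitor, a lower number a stronger inhibitor), the lowest number among the three measured compounds. Compound 2 `CCC(=O)OCc1c(F)c(N)c2c(=O)cc(-c3ccc(N)c(F)c3)oc2c1F` gives 130 nM, and compound 3 `CN(C)CC(=O)OCc1c(F)c(N)c2c(=O)cc(-c3ccc(N)c(F)c3)oc2c1F` gives 26 nM. Compound 4 `CN(C)CCCOCc1c(F)c(N)c2c(=O)cc(-c3ccc(N)c(F)c3)oc2c1F` differs from compound 1 by 3-(dimethylamino)propoxy in place of hydrogen on a saturated chain carbon bound to an aromatic carbon. For the measured compounds named here, the steps that bear on it are the two other substitutions at the same saturated chain carbon: a 10-fold higher number from compound 1 to compound 2 (1.00 log units; beyond the scatter), and a 2.0-fold higher number from compound 1 to compound 3 (0.30 log units; within the scatter); between those two compounds, a 5.0-fold lower number from compound 2 to compound 3 (0.70 log units; beyond the scatter). Compound 4 carries the dimethylamino seen in compound 3, but within a 3-(dimethylamino)propoxy group lacking a carbonyl, so the expected step is a 3.1-fold higher number from compound 1 to compound 4 (0.49 log units; beyond the scatter), a modest weakening at most. Compound 4 is therefore estimated at 40 nM, with a range of 13 nM to 130 nM.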

Compound 4, half-maximal inhibitory concentration: > 10000 nM
Compound 4 was reported as a limit; the forecaster's own chance of this, stated with the estimate: 2%; at least 250-fold (2.39 log units) between middle value and limit.
By their numbers in this assay, from the lowest: compounds 1 and 3 (each within the scatter of the next); then compound 2. At a limit, above all of these: compound 4.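

In this assay compound 4 is reported only as a limit, not a number: the limit of > 10000 nM in this assay, at which 1 of the 4 values shown sits.

Substitution at this saturated chain carbon thus ranges far wider than the two esters suggested, with 3-(dimethylamino)propoxy giving an at least 760-fold higher number from compound 1 to compound 4 (2.88 log units; beyond the scatter). The dimethylamino group alone does not preserve the number: 3-(dimethylamino)propyl in place of ((dimethylamino)methyl)carbonyl on the oxygen gives an at least 380-fold higher number from compound 3 to compound 4 (2.58 log units; beyond the scatter), and in place of propanoyl it gives an at least 76-fold higher number from compound 2 to compound 4 (1.88 log units; beyond the scatter).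

As far as these compounds go, it remains open whether the shift follows the missing carbonyl, the chain length or both. A hydroxyl, a methoxy or a 4-(dimethylamino)butanoyloxy group at this carbon would separate these.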